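Replacing a Chain End on Compound 2

The source may report more compounds than this note shows. Statements on the series, on what has been measured and on what is new or still open speak of the compounds shown alone.

Compound 1 `COC(=O)c1cccc(COc2c(-c3ccc(OCCOCCOCCN=[N+]=[N-])cc3)oc3ccccc3c2=O)c1`: 28400 nM
Compound 2 `COC(=O)c1cccc(COc2c(-c3ccc(OCCCCc4cn(CCOCCO)nn4)cc3)oc3ccccc3c2=O)c1`: 13300 nM
Compound 3 `COC(=O)c1cccc(COc2c(-c3ccc(OCCOCCn4cc(CNc5ccccc5)nn4)cc3)oc3ccccc3c2=O)c1`: > 100000 nM

In an ADME assay on L929 cells (Mus musculus) for cytotoxicity (a higher number here means a weaker inhibitor, a lower number a stronger inhibitor), compound 2 gives the lower of the two true numbers, 13300 nM. Its nearest neighbour is compound 1, with 28400 nM. The gap between these two values lies beyond the scatter. Compound 3 gives only a limit, > 100000 nM.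

Compound 4 `C#CCCCCOc1ccc(-c2oc3ccccc3c(=O)c2OCc2cccc(C(=O)OC)c2)cc1` remains unmeasured. It differs from compound 2 on a saturated chain carbon, four bonds along the chain from an oxygen on an aromatic ring: a group of 2 heavy atoms (2 carbon; no ring) in place of a group of 11 heavy atoms (6 carbon, 3 nitrogen, 2 oxygen; one five-membered aromatic ring with 3 hetero atoms), on a saturated chain carbon, four bonds along the chain from an oxygen on an aromatic ring. Going by the values given here, no measured step guides this change, so the expectation rests on compound 2 at 13300 nM and compound 1 at 28400 nM. The expected step of a 1.4-fold higher number from compound 2 to compound 4 (0.13 log units; within the scatter) is slightly upward and stays within the scatter. The estimate for compound 4 in this assay is 18000 nM, with an expected range of 6000 nM to 60000 nM.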

Compound 4, half-maximal inhibitory concentration: > 100000 nM
Compound 4: no number, only a limit (the forecaster's own chance of this, stated with the estimate: 10%); middle value at least 5.5-fold (0.74 log units) away from the limit.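

In this assay, ethynyl in place of the group of 11 heavy atoms at this saturated chain carbon gives an at least 7.5-fold higher number from compound 2 to compound 4 (0.87 log units; beyond the scatter), and but-3-yn-1-yl in place of 2-(2-azidoethoxy)ethoxy gives an at least 3.5-fold higher number from compound 1 to compound 4 (0.54 log units; beyond the scatter). The chain end at this position therefore matters, although a long chain end alone does not set the outcome, as compound 3 goes against that reading. Compound 4 gives only a limit, so both steps are lower bounds: the limit of > 100000 nM in this assay, at which 2 of the 4 values shown sit.

As far as these compounds go, how far compound 4 lies beyond that limit stays unknown. Also open, from the compounds shown here alone, is whether an amine or a carboxylic acid at this chain end would bring the number back towards that of compound 2.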